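Replacing Acetamido with an Oxazole on a Cytotoxicity Read-out

The source may report more compounds than this note shows. Statements on the series, on what has been measured and on what is new or still open speak of the compounds shown alone.

Measured so far:
compound 1 `CC(=O)Nc1cccc(C(=O)N2CCCC(C(=O)Nc3ccc(Cl)cc3)C2)c1` with 4%
compound 2 `CCc1cccc(NC(=O)C2CCCN(C(=O)c3cc(C(F)(F)F)cc(C(F)(F)F)c3)C2)c1` with 0%

Two compounds have been run in an ADME assay on PC-3 cells (Homo sapiens) for cytotoxicity, read by WST assay, tested at 100 uM; a higher number here means more inhibition at the concentration tested (going by the name of the read-out), a lower number less inhibition. Compound 1 `CC(=O)Nc1cccc(C(=O)N2CCCC(C(=O)Nc3ccc(Cl)cc3)C2)c1` gives 4%, and compound 2 `CCc1cccc(NC(=O)C2CCCN(C(=O)c3cc(C(F)(F)F)cc(C(F)(F)F)c3)C2)c1` gives 0%. The two numbers lie within the usual scatter of each other, so neither compound can be set above the other; both show little inhibition at the concentration tested. Going by the values given here, no step between compounds that differ in one place has been measured, so nothing is known about how any single change moves this read-out.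

The compound now to be measured is compound 3 `O=C(Nc1ccc(Cl)cc1)C1CCCN(C(=O)c2cccc(-c3cnco3)c2)C1`. It differs from compound 1 in one place: 1,3-oxazol-5-yl in place of acetamido on an aromatic carbon. Among the compounds with values here, with both measured compounds near zero and no measured step to lean on, the step from compound 1 to compound 3 is expected to be a number 2 percentage points higher from compound 1 to compound 3 (within the scatter), that is, none beyond the scatter. For compound 3 the estimate in this assay is 6%, in a range from -6% to 22%.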

Compound 3, a percentage reported as inhibition, at one concentration (the size of the read-out at that concentration, not a potency): 0%
Compound 3: the middle estimate sits 6 percentage points above what was measured; measured number inside the range.
By their numbers in this assay, from the lowest: compounds 2, 3 and 1 (each within the scatter of the next).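

In this assay, going by these compounds alone, the exchange of acetamido for 1,3-oxazol-5-yl on an aromatic carbon, meta to a large group, gives the first step that can be read at any single position, a number 4 percentage points lower from compound 1 to compound 3 (within the scatter). This position therefore accepts a five-membered aromatic ring with 2 hetero atoms in place of an open-chain group, and the loss of the hydrogen-bond donor of acetamido, without any inhibition emerging beyond the scatter at the concentration tested. No independent measurement bears on this result, so the flat step stands as an observation without an explanation.

From the compounds shown here alone, whether any group at this aromatic carbon can move the read-out beyond the scatter remains open, since acetamido and 1,3-oxazol-5-yl give the same picture, and what a carboxylic acid, an amine or a longer chain would do there is still to be seen. Going by these compounds, it is also open whether the same exchange would read alike on a core other than that of compound 1, as this single step comes from one pair of compounds.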